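The source may report more compounds than this note shows. Statements on the series, on what has been measured and on what is new or still open speak of the compounds shown alone.

Of the compounds shown here, three sharing one core have been measured in a functional assay on A549 cells (Homo sapiens) for antiproliferative activity, read by MTT assay, with a stated time of 24 h; a lower number here means a stronger inhibitor, a higher number a weaker inhibitor. Compound 1 `Cc1ccc(-c2nn(-c3ccccc3)cc2-c2nc3ccccc3n2S(=O)(=O)c2ccccc2)cc1` gives 760 nM, compound 2 `Cc1ccc(-c2nn(-c3ccccc3)cc2-c2nc3ccccc3n2S(=O)(=O)c2cc(C)ccc2C)cc1` gives 270 nM, and compound 3 `O=S(=O)(c1ccccc1)n1c(-c2cn(-c3ccccc3)nc2-c2ccc(F)cc2)nc2ccccc21` gives 550 nM. Compound 3 therefore stands within the scatter of compound 1, while its number lies above that of compound 2.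

The compound now in question is compound 4 `Cc1ccc(C)c(S(=O)(=O)n2c(-c3cn(-c4ccccc4)nc3-c3ccc(F)cc3)nc3ccccc32)c1`. It differs from compound 3 in one place: 2,5-dimethylphenyl in place of phenyl on a sulfonyl sulfur. In words, this is 2,5-dimethylphenyl in place of phenyl on a sulfonyl sulfur.

The same replacement has been measured once, as a 2.8-fold lower number from compound 1 to compound 2 (0.45 log units; beyond the scatter), a modest change beyond the scatter. Within the data shown here, the only other measured step, a 1.4-fold lower number from compound 1 to compound 3 (0.14 log units; within the scatter), lies within the scatter. It shows no measurable difference between the methyl and fluoro compounds, so there is no clear sign that the fluoro in compound 3 sets it apart from compound 1. On the evidence of a 2.8-fold lower number from compound 1 to compound 2 (0.45 log units; beyond the scatter), a step of similar size towards a lower number is expected in this assay, although this rests on a single pair. The expected step is a 2.8-fold lower number from compound 3 to compound 4 (0.44 log units; beyond the scatter). Compound 4 is estimated at 200 nM, with an expected range of 100 nM to 400 nM.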

Compound 4, half-maximal inhibitory concentration: 200 nM
Beside the measured number, compound 4's estimate shows no gap at the digits printed; the range from low to high includes it.
By their numbers in this assay, from the lowest: compounds 4 and 2 (each within the scatter of the next); then compounds 3 and 1 (each within the scatter of the next).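

In this assay, 2,5-dimethylphenyl in place of phenyl on a sulfonyl sulfur gives a 2.8-fold lower number from compound 3 to compound 4 (0.44 log units; beyond the scatter), so a step that had rested on a single pair now appears on a second core, with the two steps in agreement: the same change on two cores in this assay, a 2.8-fold lower number (0.45 log units; beyond the scatter) from compound 1 to compound 2 and a 2.8-fold lower number (0.44 log units; beyond the scatter) from compound 3 to compound 4, 1.0-fold (0.01 log units) apart, within the scatter of two such steps. Fluoro in place of methyl on an aromatic carbon gives a 1.4-fold lower number from compound 2 to compound 4 (0.13 log units; within the scatter), so this change again shows no measurable difference, now with 2,5-dimethylphenyl on the sulfonyl sulfur: the same change on two cores in this assay, a 1.4-fold lower number (0.14 log units; within the scatter) from compound 1 to compound 3 and a 1.4-fold lower number (0.13 log units; within the scatter) from compound 2 to compound 4, 1.0-fold (0.01 log units) apart, within the scatter of two such steps. Among these four compounds, the group on the sulfonyl sulfur therefore separates compound 2 and compound 4 from compound 1 and compound 3, while the fluoro and methyl groups separate neither pair, and no compound here goes against this pattern.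

The compounds shown do not tell whether a single methyl on the phenyl would give part or all of this step, or how a methoxy or an amine on that ring would compare with 2,5-dimethylphenyl. They also leave open whether a chloro or a nitrile in place of the fluoro would stay as close to compound 3 and compound 4 in this assay.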